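A few compounds are considered here, and "the series" means these few. Any claim that something is new, unique, unknown or untested is made for them only; others in the source may bear on it.

Working notes on the series.

Three compounds share one core and differ only in the amine on the chain three bonds from the aryl oxygen. Compound 1 `COc1cc2c(Oc3ccc(NC(=O)c4nn(-c5ccccc5)c(=O)c5ccccc45)cc3F)ccnc2cc1OCCCN1CCCC1` gives 1130 nM in a functional assay on MDA-MB-231 cells (Homo sapiens) for cytotoxicity, read by MTT assay, with a stated time of 72 h; a higher number here means a weaker inhibitor, a lower number a stronger inhibitor. Compound 2 `COc1cc2c(Oc3ccc(NC(=O)c4nn(-c5ccccc5)c(=O)c5ccccc45)cc3F)ccnc2cc1OCCCN1CCN(C)CC1` gives 1580 nM in this assay, and compound 3 `COc1cc2c(Oc3ccc(NC(=O)c4nn(-c5ccccc5)c(=O)c5ccccc45)cc3F)ccnc2cc1OCCCN1CCC(C)CC1` gives 1480 nM. The steps between them are all small: a 1.4-fold higher number from compound 1 to compound 2 (0.15 log units; within the scatter), a 1.3-fold higher number from compound 1 to compound 3 (0.12 log units; within the scatter), and a 1.1-fold lower number from compound 2 to compound 3 (0.03 log units; within the scatter). Compound 3 therefore sits in the middle of the three numbers, indistinguishable from either neighbour in this assay.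

Compound 4 `COc1cc2c(Oc3ccc(NC(=O)c4nn(-c5ccc([N+](=O)[O-])cc5)c(=O)c5ccccc45)cc3F)ccnc2cc1OCCCN1CCC(C)CC1` moves the variation to the other end of the molecule: nitro in place of hydrogen on an aromatic carbon. Among the measured compounds shown here, no measured step touches this phenyl ring; all three recorded steps concern the amine on the chain and every one of them lies within the scatter. The only thing the data say is that the measured part of the series is flat, and nothing is known about a substituent on this ring. The working expectation is therefore a step of no clear direction, a 1.0-fold higher number from compound 3 to compound 4 (0.01 log units; within the scatter), with a wide allowance for surprise. On that basis compound 4 is estimated at 1500 nM in this assay, with a range from 500 nM to 4500 nM.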

Compound 4, half-maximal inhibitory concentration: 4010 nM
Estimate against measurement, compound 4: 2.7-fold (0.43 log units) below; the range from low to high includes it.
By their numbers in this assay, from the lowest: compounds 1, 3 and 2 (each within the scatter of the next); then compound 4.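

Among the compounds shown here, the change of hydrogen to nitro on an aromatic carbon, para to a large group, gives the only step that lies beyond the scatter in this assay: a 2.7-fold higher number from compound 3 to compound 4 (0.43 log units; beyond the scatter), a modest step toward a weaker inhibitor. This phenyl ring therefore does not share the flatness seen on the chain, where pyrrolidin-1-yl, 4-methylpiperazin-1-yl and 4-methylpiperidin-1-yl could not be told apart, for example a 1.3-fold higher number from compound 1 to compound 3 (0.12 log units; within the scatter); this rests on a single pair, compound 3 and compound 4, with the 4-methylpiperidin-1-yl chain held constant. No measurement is available that bears on the origin of this step.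

The compounds shown do not settle whether the higher number is specific to nitro or would also follow from another group at this place, such as an amine, a methoxy group, a fluorine atom or a carboxylic acid. They also leave open whether nitro gives a step of similar size when paired with the pyrrolidin-1-yl or 4-methylpiperazin-1-yl chain, so the step cannot yet be treated as independent of the amine.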